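A few compounds are considered here, and "the series" means these few. Any claim that something is new, unique, unknown or untested is made for them only; others in the source may bear on it.

Measured in a functional assay on DU-145 cells (Homo sapiens) for inhibition, read by trypan blue exclusion, with a stated time of 96 h; a higher number here means a weaker inhibitor of growth, a lower number a stronger inhibitor of growth:
- Compound 1 `Cc1ccc(CS(=O)(=O)/C(=C/c2cc(C)cc(C)c2)C(=O)c2ccc(Cl)cc2)cc1` gives 10000 nM
- Compound 2 `Cc1cc(C)cc(/C=C(\C(=O)c2ccc(Cl)cc2)S(=O)(=O)Cc2ccc(Cl)cc2)c1` gives 1000 nM
- Compound 3 `Cc1cc(C)cc(/C=C(\C(=O)c2ccc(Cl)cc2)S(=O)(=O)c2ccc(Br)cc2)c1` gives 10000 nM

Compound 1 stands level with compound 3, together the highest of the three numbers, and only compound 2 lies lower. Compound 4 `COc1ccccc1/C=C(\C(=O)c1ccc(Cl)cc1)S(=O)(=O)Cc1ccc(C)cc1` differs from compound 1 as follows: 2-methoxyphenyl in place of 3,5-dimethylphenyl on a double-bonded chain carbon bound to a double-bonded chain carbon. This puts 2-methoxyphenyl in place of 3,5-dimethylphenyl on a double-bonded chain carbon bound to a double-bonded chain carbon. Within the data shown here, no measured step touches that place. Among the measured compounds shown here, the only guides lie elsewhere: a 10-fold lower number from compound 1 to compound 2 (1.00 log units; beyond the scatter), and no change at the digits printed from compound 1 to compound 3 (within the scatter). A single change in this series has thus given either a modest step or none. A small move towards a lower number is therefore expected, with no change beyond the scatter still possible. The expected result in this assay is a 2.0-fold lower number from compound 1 to compound 4 (0.30 log units; within the scatter). Compound 4 is estimated at 5000 nM, with an expected range of 1000 nM to 20000 nM.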

Compound 4, concentration for 50% growth inhibition: 10000 nM
For compound 4 the middle estimate is 2.0-fold (0.30 log units) below the measured one; the measured number falls inside the stated range.
By their numbers in this assay, from the lowest: compound 2; then compounds 1, 3 and 4 (each within the scatter of the next).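

In this assay, among these compounds, the first measured step at this place, on a double-bonded chain carbon bound to a double-bonded chain carbon, shows no change at the digits printed from compound 1 to compound 4 (within the scatter) with 2-methoxyphenyl in place of 3,5-dimethylphenyl. The exchange keeps the heavy-atom count and the aromatic ring and adds one hydrogen-bond acceptor, with the read-out level with that of compound 1. No measured data bear on the reason for this result.

A single exchange cannot show how far this position is insensitive. An amine or a carboxylic acid on this ring remains untested among the compounds shown, as does 2-methoxyphenyl on the 4-chlorobenzyl sulfonyl background of compound 2.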